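Methoxy in place of methyl on the aryl ring

This account rests on a few compounds, and the source may have more. Where it says the series, first, only, none or still open, it means among the compounds named here.

Compound 1 `CC1=C(/C=C/C(=O)/C=C/c2ccccc2)C(C)(C)CCC1O` gives 15500 nM in a functional assay on PC-3 cells (Homo sapiens) for cytotoxicity, read by MTT assay, with a stated time of 72 h; on this read-out lower numbers stand for stronger inhibition and higher numbers for weaker inhibition. Compound 2 `CC1=C(/C=C/C(=O)/C=C/c2ccccc2F)C(C)(C)CCC1O` gives 10400 nM in this assay. Compound 3 `CC1=C(/C=C/C(=O)/C=C/c2cccc(C)c2)C(C)(C)CCC1O` gives 6200 nM in this assay.

Compound 3 has the lowest number of the three: the step of a 2.5-fold lower number from compound 1 to compound 3 (0.40 log units; beyond the scatter) lies beyond the scatter, while the step of a 1.7-fold lower number from compound 2 to compound 3 (0.22 log units; within the scatter) does not. Compound 4 `COc1cccc(/C=C/C(=O)/C=C/C2=C(C)C(O)CCC2(C)C)c1` differs from compound 3 by methoxy in place of methyl on an aromatic carbon. Within the data shown here, no measured step exchanges a methoxy, and the only steps at the aromatic ring, a 1.5-fold lower number from compound 1 to compound 2 (0.17 log units; within the scatter) and a 2.5-fold lower number from compound 1 to compound 3 (0.40 log units; beyond the scatter), are small, so a change no larger than the scatter is expected in this assay. For compound 4 the expected step is a 1.0-fold higher number from compound 3 to compound 4 (0.02 log units; within the scatter), giving an estimate of 6500 nM with a range from 3000 nM to 14000 nM.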

Compound 4, half-maximal inhibitory concentration: 6500 nM
Compound 4: the middle estimate sits on the measured number at the digits printed, within the range that was stated.
By their numbers in this assay, from the lowest: compounds 3, 4, 2 and 1 (each within the scatter of the next, the first and the last beyond it).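

In this assay the step of a 1.0-fold higher number from compound 3 to compound 4 (0.02 log units; within the scatter) shows that methoxy can replace methyl on this aromatic carbon with no readable change, although it adds a hydrogen-bond acceptor. The step of a 2.4-fold lower number from compound 1 to compound 4 (0.38 log units; beyond the scatter) gives a second group at this place that lies beyond the scatter relative to hydrogen, while a 1.6-fold lower number from compound 2 to compound 4 (0.20 log units; within the scatter) stays within it.

On these data alone, whether an amine or a carboxylic acid on this carbon would keep the number in this range remains open, as does methoxy on other ring carbons. Nothing available offers a reason for these numbers.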